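The source may report more compounds than this note shows. Statements on the series, on what has been measured and on what is new or still open speak of the compounds shown alone.

Measured in an assay on LX2 cells for inhibition of COL1A1 promoter (Homo sapiens), read by a luciferase reporter, with a stated time of 24 h, tested at 20 uM; a lower number here means a weaker effect, a higher number a stronger effect of the compound at the concentration tested:

compound 1 `CN(C)c1ccc2c(=O)c(C(=O)Nc3cc(F)cc(F)c3)cn(-c3ccc(Cl)c(OCCCCCCC[N+]4(C)CCCCC4)c3)c2n1`: 57.3%
compound 2 `CN1CC[N+](C)(CCCCCCCOc2cc(-n3cc(C(=O)Nc4cc(F)cc(F)c4)c(=O)c4ccc(N(C)C)nc43)ccc2Cl)CC1`: 27.5%
compound 3 `Cc1ccc(-n2cc(C(=O)Nc3cc(F)cc(F)c3)c(=O)c3ccc(N(C)C)nc32)cc1OCCCCCCC[N+](C)(C)C1CCCCC1`: 32.3%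

Compound 3 stands second highest of the three numbers; its nearest neighbour is compound 2, within the scatter, and its furthest is compound 1, beyond the scatter.

Compound 4 `CN(C)c1ccc2c(=O)c(C(=O)Nc3cc(F)cc(F)c3)cn(-c3ccc(Cl)c(OCCCCCCC[N+](C)(C)C4CCCCC4)c3)c2n1` differs from compound 3 by chloro in place of methyl on an aromatic carbon. For the measured compounds named here, the only measured step, a number 29.8 percentage points lower from compound 1 to compound 2 (beyond the scatter), alters the group on the saturated chain carbon and leaves the aromatic substituent untouched, so it does not bear on this change. Going by the values given here, no measured pair isolates methyl against chloro at this position; compound 1 and compound 3 differ there but also at the chain end. With nothing to guide direction, the step to compound 4 is expected to stay within the scatter: a number 2.7 percentage points higher from compound 3 to compound 4 (within the scatter). Compound 4 is therefore estimated at 35%, between 15% and 55%.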

Compound 4, a percentage reported as inhibition, at one concentration (the size of the read-out at that concentration, not a potency): 37.6%
For compound 4 the middle estimate is 2.6 percentage points below the measured one; the measured number falls inside the stated range.
By their numbers in this assay, from the lowest: compounds 2, 3 and 4 (each within the scatter of the next, the first and the last beyond it); then compound 1.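

In this assay, chloro in place of methyl on this aromatic carbon gives a number 5.3 percentage points higher from compound 3 to compound 4 (within the scatter) and so shows no separation between the two groups. With chloro held constant, the chain-end group still separates the compounds: the group with a six-membered ring of carbon only gives a number 10.1 percentage points higher from compound 2 to compound 4 (beyond the scatter) and also a number 19.7 percentage points lower from compound 1 to compound 4 (beyond the scatter) when compared with the two hetero-atom-containing ring groups. No supporting evidence bears on these results.
Going by these compounds, whether methoxy or trifluoromethyl at this aromatic carbon would behave like methyl and chloro remains open. So does the effect of a shorter chain on these steps.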